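The source may hold more compounds than are shown below. What is called first, only, known or untested is meant among the compounds shown, and "the series" means these compounds.

Of the compounds shown here, three built on one shared core have been measured in a functional assay on MCF7 cells (Homo sapiens) for cytotoxicity, read by MTT assay, with a stated time of 72 h; on this read-out higher numbers stand for weaker inhibition of growth and lower numbers for stronger inhibition of growth. Compound 1 `CS/C(=N\C(=O)c1ccco1)NC(=O)c1ccco1` carries a methylsulfanyl group on the central carbon, and in this assay compound 1 gives 56100 nM. Compound 2 `C[Se]/C(=N\C(=O)c1cccs1)NC(=O)c1cccs1` carries a methylselanyl group there instead and has different amide arms; in this assay compound 2 gives 3.4 nM. Compound 3 `C[Se]/C(=N\C(=O)c1cnc2ccccc2c1)NC(=O)c1cnc2ccccc2c1` keeps the selenium-bearing group but has yet another pair of amide arms, and in this assay compound 3 gives 660 nM. That places compound 3 second highest of the three numbers: far below compound 1 and far above compound 2, both gaps well beyond the scatter.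

Compound 4 `CS/C(=N\C(=O)c1cnc2ccccc2c1)NC(=O)c1cnc2ccccc2c1` differs from compound 3 in a single place: a group of 2 heavy atoms (1 carbon, 1 sulfur; no ring) in place of a group of 2 heavy atoms (1 carbon, 1 selenium; no ring), on a carbon with a double bond to nitrogen. For the measured compounds named here, no measured pair differs only in this way, so the size of this step has not been seen directly. Going by the values given here, compound 1, the only measured compound with methylsulfanyl, gives 56100 nM, yet it also differs from compound 2 in its arms, so its gap to compound 2 cannot be credited to the group alone. Still, the step from compound 3 to compound 4 is expected to be a marked loss of potency, about a 30-fold higher number from compound 3 to compound 4 (1.48 log units; beyond the scatter). Compound 4 is therefore estimated to give roughly 20000 nM in this assay, with a plausible range from 3000 nM to 150000 nM.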

Compound 4, concentration for 50% growth inhibition: 23900 nM
The estimate for compound 4 lay 1.2-fold (0.08 log units) below the measured number; the range from low to high includes it.
By their numbers in this assay, from the lowest: compound 2; then compound 3; then compound 4; then compound 1.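

In this assay, replacing the selenium-bearing group with methylsulfanyl on a carbon with a double bond to nitrogen, whose other neighbours are two amide-type nitrogens, gives a 36-fold higher number from compound 3 to compound 4 (1.56 log units; beyond the scatter) and so means much weaker inhibition of growth. This is the first pair in which nothing else changes: the earlier compounds differed in their amide arms as well, so only here can a gap be credited to this one exchange of selenium for sulfur, and this position is shown to matter greatly with these arms in place. No measurement shown explains why the step is so large.

The compounds shown leave open whether the exchange has a similar size with the amide arms of compound 1 or compound 2, since a single pair cannot show whether the step carries over to other arms. They also leave open how other groups on this carbon would compare, such as a longer chain like ethylsulfanyl, or an amine.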